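The source may hold more compounds than are shown below. What is called first, only, known or untested is meant among the compounds shown, and "the series" means these compounds.

Measured compounds in this series:

Compound 1 `CCN1CCN(CCCOc2cc3nccc(Oc4c(F)cc(NC(=O)NN5C(=O)CSC5c5c(F)cccc5F)cc4F)c3cc2OC)CC1` gives 350 nM in a functional assay on A549 cells (Homo sapiens) for antiproliferative activity, read by MTT assay, with a stated time of 72 h; a higher number here means a weaker inhibitor, a lower number a stronger inhibitor.
Compound 3 `COc1cc2c(Oc3c(F)cc(NC(=O)NN4C(=O)CSC4c4c(F)cccc4F)cc3F)ccnc2cc1OCCCN1CCC(C)CC1` gives 970 nM in this assay.
Compound 2 `COc1cc2c(Oc3c(F)cc(NC(=O)NN4C(=O)CSC4c4c(F)cccc4F)cc3F)ccnc2cc1OCCCN1CCc2sccc2C1` gives only a limit of the assay in this assay, > 20000 nM.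

Compound 3 holds the higher of the two numbers, its nearest neighbour being compound 1, with a 2.8-fold higher number from compound 1 to compound 3 (0.44 log units; beyond the scatter). Compound 2 sits at the limit, see (the limit of > 20000 nM in this assay, at which 1 of the 3 values shown sits), so the step of an at least 20-fold lower number from compound 2 to compound 3 (1.31 log units; beyond the scatter) and the step of an at least 57-fold higher number from compound 1 to compound 2 (1.75 log units; beyond the scatter) are known only as bounds.

The unmeasured compound 4 `COc1cc2c(Oc3c(F)cc(NC(=O)NN4C(=O)CSC4c4c(F)cccc4F)cc3F)ccnc2cc1OCCCN1CCN(C)CC1` differs from compound 3 by 4-methylpiperazin-1-yl in place of 4-methylpiperidin-1-yl on a saturated chain carbon, three bonds along the chain from an oxygen on an aromatic ring. For the measured compounds named here, the one measured step that bears on this change is the step from compound 1 to compound 3, a 2.8-fold higher number from compound 1 to compound 3 (0.44 log units; beyond the scatter), where a 4-methylpiperidin-1-yl in place of a 4-ethylpiperazin-1-yl at the same position raised the number modestly. Going by the values given here, compound 4 carries a 4-methylpiperazin-1-yl at that position, so the reverse direction of that step is the relevant guide; the ethyl of compound 1 against the methyl of compound 4 is the only remaining difference, and no measured pair speaks to it.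

The number for compound 4 in this assay is therefore expected to drop modestly, with a 2.4-fold lower number from compound 3 to compound 4 (0.38 log units; beyond the scatter) landing it close to compound 1. The estimate for compound 4 is 400 nM, with a range from 150 nM to 1200 nM.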

Compound 4, half-maximal inhibitory concentration: 510 nM
Compound 4: the middle estimate sits 1.3-fold (0.11 log units) below what was measured; the measured number falls inside the stated range.
By their numbers in this assay, from the lowest: compounds 1, 4 and 3 (each within the scatter of the next, the first and the last beyond it). At a limit, above all of these: compound 2.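

In this assay, neither single change separates the compounds on its own: 4-methylpiperazin-1-yl in place of 4-methylpiperidin-1-yl gives a 1.9-fold lower number from compound 3 to compound 4 (0.28 log units; within the scatter), and 4-methylpiperazin-1-yl against 4-ethylpiperazin-1-yl gives a 1.5-fold higher number from compound 1 to compound 4 (0.16 log units; within the scatter). For the compounds shown here, the gap between compound 1 and compound 3, the only one of these three comparisons beyond the scatter, therefore now resolves into two steps that each lie within it, and the swap of ring carbon for ring nitrogen has no readable effect at this position when taken alone. Compound 2 remains a limit of the assay and not a number: the limit of > 20000 nM in this assay, at which 1 of the 4 values shown sits.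

Compound 4 also stands clear of that limit, with an at least 39-fold lower number from compound 2 to compound 4 (1.59 log units; beyond the scatter), so the large loss seen with the group of compound 2 holds against the piperidine and against both piperazines. The compounds shown leave open whether that loss follows from the sulfur-bearing five-membered aromatic ring or from the larger fused group as a whole. They also leave open how a morpholine ring, a piperazine with hydrogen on the ring nitrogen, or a shorter or longer chain than propyl would read in this assay.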